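The compounds below may be only part of what the source reports. "The series", "measured", "known", "first", "only" and "open" are said of these compounds alone.

Of the compounds shown here, three built on the same saturated bicyclic core have been tested in a functional assay on MCF7 cells (Homo sapiens) for antiproliferative activity, read by sulforhodamine B assay, with a stated time of 48 h; a higher number here means a weaker inhibitor, a lower number a stronger inhibitor. Compound 1 `CC1(C)[C@@H]2CC3=NCC(=O)O[C@@]3(C)[C@H]1C2` gives 22000 nM. Compound 2 `CC(C)(C)OC(=O)n1cnc(C[C@H]2N=C3C[C@H]4C[C@H](C4(C)C)[C@@]3(C)OC2=O)c1` gives 142000 nM. Compound 3 `CC(C)(C)OC(=O)NCCC[C@@H]1N=C2C[C@@H]3C[C@@H](C3(C)C)[C@]2(C)OC1=O` gives 6300 nM, the lowest of the three numbers; its nearest neighbour is compound 1, whose gap already lies beyond the usual scatter, and its furthest is compound 2. Among the measured compounds shown here, no two measured compounds differ in only one place, so no single-change step can be read directly from what has been measured.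

Compound 4 `CC(C)(C)OC(=O)NCCCC[C@@H]1N=C2C[C@@H]3C[C@@H](C3(C)C)[C@]2(C)OC1=O` remains to be measured. It differs from compound 3 in one respect: ((tert-butoxycarbonyl)amino)methyl in place of (tert-butoxycarbonyl)amino on a saturated chain carbon, three bonds along the chain from a saturated ring carbon. The terminal carbamate is kept and the chain between it and the core is lengthened. For the measured compounds named here, with no measured step of this kind available, and the donor and acceptor pattern unchanged, compound 4 is expected to stay close to compound 3, with an estimated step from compound 3 to compound 4 of a 1.1-fold lower number from compound 3 to compound 4 (0.02 log units; within the scatter) that should fall within the scatter. Compound 4 is accordingly estimated at 6000 nM, within a range of 2500 nM to 15000 nM.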

Compound 4, half-maximal inhibitory concentration: 17000 nM
Compound 4: middle estimate off by 2.8-fold (0.45 log units), on the low side, and the stated range ends below it.
By their numbers in this assay, from the lowest: compound 3; then compounds 4 and 1 (each within the scatter of the next); then compound 2.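

Among the compounds shown here, the pair gives the first single-change reading: in this assay, ((tert-butoxycarbonyl)amino)methyl in place of (tert-butoxycarbonyl)amino on a saturated chain carbon, three bonds along the chain from a saturated ring carbon, gives a 2.7-fold higher number from compound 3 to compound 4 (0.43 log units; beyond the scatter). The length of the chain carrying the terminal carbamate therefore matters at this position, modestly but beyond the scatter, even though the two groups have the same hydrogen-bond donor and acceptor counts. Nothing shown here offers an explanation for this step.

As far as these compounds go, a single step fixes no trend, so it remains open whether a longer chain would continue in the same direction. Also open, from the compounds shown here alone, is whether a free amine or a carboxylic acid at the chain end would keep the number of compound 3 or move it.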